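Chloro in Place of Fluoro on Compound 3

The source may report more compounds than this note shows. Statements on the series, on what has been measured and on what is new or still open speak of the compounds shown alone.

Of the compounds shown here, three that share one core have been measured. Compound 1 `O=C(CSc1nc(Nc2ccccc2)c2ccccc2n1)Nc1cccc(Cl)c1` gives 12600 nM in a functional assay on PC-3 cells (Homo sapiens) for inhibition, read by MTT assay, with a stated time of 72 h; on this read-out lower numbers stand for stronger inhibition and higher numbers for weaker inhibition. Compound 2 `COc1cccc(NC(=O)CSc2nc(Nc3ccccc3)c3ccccc3n2)c1` gives 11600 nM in this assay, and compound 3 `O=C(CSc1nc(Nc2ccccc2)c2ccccc2n1)Nc1ccc(F)cc1` gives 9560 nM. The three steps between them are small: a 1.1-fold lower number from compound 1 to compound 2 (0.04 log units; within the scatter), a 1.3-fold lower number from compound 1 to compound 3 (0.12 log units; within the scatter) and a 1.2-fold lower number from compound 2 to compound 3 (0.08 log units; within the scatter). Compound 3 thus shows the lowest of the three numbers, but its gaps to compound 2 and to compound 1 both lie within the scatter, so no order among the three can be read.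

Compound 4 `O=C(CSc1nc(Nc2ccccc2)c2ccccc2n1)Nc1ccc(Cl)cc1` is not yet measured. It differs from compound 3 in one place: chloro in place of fluoro on an aromatic carbon. Among the measured compounds shown here, no measured step isolates this exact exchange. The step from compound 1 to compound 3 swaps a 3-chlorophenyl for a 4-fluorophenyl and was within the scatter, and the step from compound 1 to compound 2, which exchanges chloro for methoxy, was likewise within the scatter. Since every halogen-related change seen so far has stayed within the scatter, compound 4 is expected to show no step beyond the scatter, a 1.1-fold lower number from compound 3 to compound 4 (0.03 log units; within the scatter). The estimate for compound 4 in this assay is therefore 9000 nM, with a range from 4000 nM to 20000 nM.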

Compound 4, half-maximal inhibitory concentration: 12900 nM
Compound 4: the middle estimate sits 1.4-fold (0.16 log units) below what was measured, within the range that was stated.
By their numbers in this assay, from the lowest: compounds 3, 2, 1 and 4 (each within the scatter of the next).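

Among the compounds shown here, with this assay the exchange of fluoro for chloro on this aromatic carbon, para to a large group, can now be read on its own, and it gives a 1.3-fold higher number from compound 3 to compound 4 (0.13 log units; within the scatter) as its single step, so this position shows no readable difference from that exchange. The new compound also shows that the place of the chloro makes no readable difference in this set, since 4-chlorophenyl in place of 3-chlorophenyl gives a 1.0-fold higher number from compound 1 to compound 4 (0.01 log units; within the scatter) as its step, while 4-chlorophenyl in place of 3-methoxyphenyl gives a 1.1-fold higher number from compound 2 to compound 4 (0.05 log units; within the scatter) and likewise leaves the two compounds unseparated. Nothing shown here bears on what lies behind these steps.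

On these data alone, all four compounds carry only a chloro, fluoro or methoxy on this ring, so it remains open whether an amine, a carboxylic acid or a longer chain there would take the number beyond the scatter. As far as these compounds go, the phenylamino group and the shared core are the same throughout, so what an exchange at either of those places would do also remains open.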